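The compounds below may be only part of what the source reports. "The series", "measured", "known", "first", "only" and "open" are said of these compounds alone.

Measured compounds:
- compound 1, `Nc1ccccc1NC(=O)c1ccc(CSC(=S)N2CCN(Cc3ccccn3)CC2)cc1`: 20.7%
- compound 2, `Nc1ccccc1NC(=O)c1ccc(CSC(=S)N2CCN(c3ncccn3)CC2)cc1`: 24%

In a functional assay on A-375 cells (Homo sapiens) for antiproliferative activity, read by CCK-8 assay, with a stated time of 72 h, tested at 2 uM (on this read-out higher numbers stand for a stronger effect at the one concentration tested and lower numbers for a weaker effect), compound 1 gives 20.7%, the smaller of the two numbers shown, while compound 2 gives 24%; the step of a number 3.3 percentage points higher from compound 1 to compound 2 (within the scatter) is too small to separate the two compounds.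

Compound 3 is `Nc1ccccc1NC(=O)c1ccc(CSC(=S)N2CCN(c3ccccc3F)CC2)cc1`. It differs from compound 1 by 2-fluorophenyl in place of (pyridin-2-yl)methyl on an amine nitrogen in a ring. For the measured compounds named here, the only measured step that bears on this change is the one from compound 1 to compound 2, which also removes the (pyridin-2-yl)methyl group from the same ring nitrogen and attaches an aromatic ring directly; that step was a number 3.3 percentage points higher from compound 1 to compound 2 (within the scatter). On that basis no step beyond the scatter is expected in this assay for compound 3, in either direction. The expected step is a number 2.3 percentage points higher from compound 1 to compound 3 (within the scatter). Compound 3 is therefore estimated at 23%, with a range from 12% to 38%.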

Compound 3, a percentage reported as inhibition, at one concentration (the size of the read-out at that concentration, not a potency): 18.7%
For compound 3 the middle estimate is 4.3 percentage points above the measured one; low and high end bracket the measured number.
By their numbers in this assay, from the lowest: compounds 3, 1 and 2 (each within the scatter of the next).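

In this assay, 2-fluorophenyl in place of (pyridin-2-yl)methyl gives a number 2 percentage points lower from compound 1 to compound 3 (within the scatter) on the same ring nitrogen, and 2-fluorophenyl in place of pyrimidin-2-yl gives a number 5.3 percentage points lower from compound 2 to compound 3 (within the scatter) at that site. A ring of carbon only, with no hydrogen-bond acceptor, therefore gives a number that cannot be told apart from those of the two nitrogen-containing groups, so the three compounds cannot be ranked. Nothing available explains why these numbers stay so close.

From the compounds shown here alone, whether a phenyl ring without fluorine, or an open chain ending in an amine or a carboxylic acid, would give a step beyond the scatter at this nitrogen stays open. With a single concentration, these numbers also leave the potency of the compounds unknown.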